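This account rests on a few compounds, and the source may have more. Where it says the series, first, only, none or still open, it means among the compounds named here.

Series notes. Compound 1 `O=C(CSc1nc2ccc(NC(=O)CCl)cc2s1)NCc1ccccc1` is the reference. In a functional assay on MCF7 cells (Homo sapiens) for cytotoxicity, read by MTT assay, with a stated time of 48 h (on this read-out lower numbers stand for stronger inhibition and higher numbers for weaker inhibition), compound 1 gives 4200 nM, the lowest of the three numbers shown. Compound 3 `CNC(=O)CSc1nc2ccc(NC(=O)CCl)cc2s1` gives 5000 nM; the step of a 1.2-fold higher number from compound 1 to compound 3 (0.08 log units; within the scatter) is within the scatter. Among the compounds with values here, compound 2 `COc1ccc(CNC(=O)CSc2nc3ccc(NC(C)=O)cc3s2)cc1` gives 20500 nM, the furthest from compound 1; it differs from compound 1 in two places, so no single step is drawn for that pair.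

Compound 4 `O=C(CSc1nc2ccc(NC(=O)c3ccccc3)cc2s1)NCc1ccccc1` is not yet measured. The change from compound 1 is phenyl in place of chloromethyl on a carbonyl carbon. Within the data shown here, no measured step alters this carbonyl alone. The step from compound 1 to compound 3 touches the other end of the shared core and is within the scatter, so it says nothing about the chloromethyl. Compound 2, which among other things carries methyl in place of chloromethyl on that carbonyl carbon, gives the highest number of the three. The expectation for compound 4 in this assay is therefore a step towards a higher number, a 2.9-fold higher number from compound 1 to compound 4 (0.46 log units; beyond the scatter), with wide uncertainty. Compound 4 is estimated at 12000 nM, in the range 4000 nM to 36000 nM.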

Compound 4, half-maximal inhibitory concentration: 35600 nM
The estimate for compound 4 lay 3.0-fold (0.47 log units) below the measured number; low and high end bracket the measured number.
By their numbers in this assay, from the lowest: compounds 1 and 3 (each within the scatter of the next); then compounds 2 and 4 (each within the scatter of the next).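

In this assay, phenyl in place of chloromethyl on a carbonyl carbon gives an 8.5-fold higher number from compound 1 to compound 4 (0.93 log units; beyond the scatter), the only single step shown that alters this carbonyl alone. Within the data shown here, the position therefore responds to a change on its own, without the second difference that blurred the reading of compound 2, whereas the one other single step, a 1.2-fold higher number from compound 1 to compound 3 (0.08 log units; within the scatter), leaves the number within the scatter. Nothing available bears on why the number rises at this carbonyl.

Because chloromethyl leaves and phenyl enters in one step, the step cannot separate the loss of the chlorine-bearing group from the arrival of the ring. Bromomethyl, an aminomethyl group or a longer chain such as 3-chloropropyl on this carbonyl carbon, with the rest of compound 1 kept, would help to tell these apart.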